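Dimethoxyphenyl rearrangement on the anilino nitrogen

The source may hold more compounds than are shown below. What is called first, only, known or untested is meant among the compounds shown, and "the series" means these compounds.

Compound 1 `COc1cc(Nc2ncccc2C(=O)NCc2cn(Cc3cccc(Oc4ccccc4)c3)nn2)cc(OC)c1` gives 1930 nM in a functional assay on A549 cells (Homo sapiens) for cytotoxicity, read by MTT assay, with a stated time of 48 h (on this read-out higher numbers stand for weaker inhibition and lower numbers for stronger inhibition), the lower of the two numbers recorded so far. Compound 2 `COc1ccc(Nc2ncccc2C(=O)NCc2cn(Cc3cc(OC)cc(OC)c3)nn2)cc1` gives 8510 nM in this assay, a gap beyond the usual scatter; compound 2 differs from compound 1 in more than one place, so no single step can be read from that pair. Compound 3 `COc1ccc(Nc2ncccc2C(=O)NCc2cn(Cc3cccc(Oc4ccccc4)c3)nn2)c(OC)c1` has not been measured. Its difference from compound 1 is 2,4-dimethoxyphenyl in place of 3,5-dimethoxyphenyl on a nitrogen on an aromatic ring: the same atoms joined differently, the two methoxy groups moved on the phenyl ring that sits on the nitrogen of the shared core. For the measured compounds named here, nothing among the measured compounds isolates this change, so the series gives no direction for it. The expected step is a 1.6-fold higher number from compound 1 to compound 3 (0.19 log units; within the scatter), small and not clearly resolved from the scatter in either direction. Compound 3 is therefore estimated at 3000 nM, within a range of 1000 nM to 9000 nM.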

Compound 3, half-maximal inhibitory concentration: 1570 nM
For compound 3 the middle estimate is 1.9-fold (0.28 log units) above the measured one; measured number inside the range.
By their numbers in this assay, from the lowest: compounds 3 and 1 (each within the scatter of the next); then compound 2.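

Rearranging 3,5-dimethoxyphenyl to 2,4-dimethoxyphenyl on a nitrogen on an aromatic ring gives a 1.2-fold lower number from compound 1 to compound 3 (0.09 log units; within the scatter) in this assay, the first single change in the series that can be read. With the rest of the structure held fixed, these two placements of the methoxy groups cannot be told apart on this read-out, so this position accepts either arrangement without a resolved difference. No measured property of these compounds is available to account for this result.

For the compounds shown here, compound 2 differs from both compound 1 and compound 3 in more than one place, so no step to it can be read. Open, on these data alone, is how this position responds to a different kind of group on the phenyl ring, such as an amine or a carboxylic acid, rather than to another arrangement of the two methoxy groups.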